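Cyclohexyl for propyl on the ring nitrogen

A few compounds are considered here, and "the series" means these few. Any claim that something is new, unique, unknown or untested is made for them only; others in the source may bear on it.

Going by the values given here, compound 2 `CCCn1c(-c2ccc(OCc3c(-c4c(Cl)cccc4Cl)noc3C(C)C)cc2)nc2ccc(C(=O)O)cc21` gives 9.3 nM in an assay on Huh-7 cells for agonist activity at Bile acid receptor (Homo sapiens), read by a luciferase reporter (a higher number here means that more compound is needed for the effect, a lower number that less compound is needed), the higher of the two numbers so far, but compound 1 `CC(C)c1onc(-c2c(Cl)cccc2Cl)c1COc1ccc(-c2nc3ccc(C(=O)O)cc3n2CC2CCCCC2)c(F)c1` at 7.8 nM lies within the scatter of it, so no order between the two can be claimed. Compound 3 `CC(C)c1onc(-c2c(Cl)cccc2Cl)c1COc1ccc(-c2nc3ccc(C(=O)O)cc3n2C2CCCCC2)cc1` differs from compound 2 by cyclohexyl in place of propyl on an aromatic nitrogen. Among the compounds with values here, no step between measured compounds isolates this change, so only an expectation is possible: a step from compound 2 to compound 3 within the scatter, or a small one toward a lower number, is expected, a 1.2-fold lower number from compound 2 to compound 3 (0.07 log units; within the scatter). Compound 3 is estimated at 8 nM, between 3 nM and 25 nM, in this assay.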

Compound 3, half-maximal effective concentration: 4.21 nM
Compound 3: the middle estimate sits 1.9-fold (0.28 log units) above what was measured, within the range that was stated.
By their numbers in this assay, from the lowest: compounds 3, 1 and 2 (each within the scatter of the next, the first and the last beyond it).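

On the aromatic nitrogen, cyclohexyl in place of propyl gives a 2.2-fold lower number from compound 2 to compound 3 (0.34 log units; beyond the scatter) in this assay. Going by these compounds alone, this is the first change isolated at a single place, and it shows that this nitrogen accepts a six-membered non-aromatic ring of carbon only with a modest step toward a lower number. Nothing at hand gives a reason for the step. Whether the ring itself or simply the added carbon accounts for it stays open. A hexyl chain or a cyclopropyl ring on this nitrogen would separate the two.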